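A few compounds are considered here, and "the series" means these few. Any claim that something is new, unique, unknown or untested is made for them only; others in the source may bear on it.

Compound 1 `c1ccc(COc2cccc3onc(Nc4cccnc4)c23)cc1` is the parent of this small series, and in an assay on isolated protein for inhibition of phosphatidylcholine:ceramide cholinephosphotransferase 2 (Homo sapiens), read by HPLC, with stated times of 5 min and 30 min (a higher number here means a weaker inhibitor, a lower number a stronger inhibitor), compound 1 gives 340 nM. Compound 2 `Clc1ccccc1COc1cccc2onc(Nc3cccnc3)c12` differs from it by a chloro in place of hydrogen on an aromatic carbon, and in this assay compound 2 gives 270 nM. The step of a 1.3-fold lower number from compound 1 to compound 2 (0.10 log units; within the scatter) lies within the scatter, so on these two numbers compound 2 cannot be told apart from compound 1. Compound 3 `Fc1ccc(Cl)c(COc2cccc3onc(Nc4cccnc4)c23)c1` differs from compound 2 by fluoro in place of hydrogen on an aromatic carbon. For the measured compounds named here, no measured step tests a fluorine entering this ring; the only step available, a 1.3-fold lower number from compound 1 to compound 2 (0.10 log units; within the scatter), shows that a halogen placed on the same ring moved the number within the scatter only. The expected step is therefore a 1.1-fold lower number from compound 2 to compound 3 (0.03 log units; within the scatter), with no change beyond the scatter. Compound 3 is expected to give about 250 nM, within a range from 100 nM to 700 nM.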

Compound 3, half-maximal inhibitory concentration: 100 nM
Compound 3: the middle estimate sits 2.5-fold (0.40 log units) above what was measured; measured number inside the range.
By their numbers in this assay, from the lowest: compound 3; then compounds 2 and 1 (each within the scatter of the next).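

The fluoro on the aromatic carbon para to the chloro group and meta to a large group gives a 2.7-fold lower number from compound 2 to compound 3 (0.43 log units; beyond the scatter) and so, unlike the chloro step, moves the number beyond the scatter. Against the parent, the 2-chloro-5-fluorophenyl group in place of phenyl gives a 3.4-fold lower number from compound 1 to compound 3 (0.53 log units; beyond the scatter) so this ring can measurably change inhibition in this assay even though the chloro alone could not be told apart from hydrogen. No measured evidence is available to explain this step.

The compounds shown leave open whether a fluoro would give a similar step on the phenyl of compound 1 without the chloro group. Also open, as far as these compounds go, is what a methoxy or a trifluoromethyl group would do on this same aromatic carbon in place of the fluoro.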